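Trifluoromethoxy in Place of Trifluoromethyl on a Weak Core

The source may hold more compounds than are shown below. What is called first, only, known or untested is meant among the compounds shown, and "the series" means these compounds.

Compound 1 `O=C(O)c1csc([C@H]2CC[C@@H]3[C@@H](COc4ccc(C(F)(F)F)cc4)[C@H](O)C[C@@H]3O2)n1` carries a trifluoromethyl group on its aromatic ring. In an assay on HEK293 cells for agonist activity at prostaglandin E2 receptor EP2 subtype (Homo sapiens), read by a beta-galactosidase reporter and beta-arrestin recruitment, with a stated time of 90 min (a lower number here means that less compound is needed, a higher number that more compound is needed for the effect), compound 1 gives only a limit, > 10000 nM, which is not a number but the point at which the measurement stops. Compound 2 `O=C(O)c1csc([C@H]2CC[C@@H]3[C@@H](/C=C/COc4ccccc4)[C@H](O)C[C@@H]3O2)n1`, a relative with a different connection to its aromatic ring, is likewise known only by a limit in this assay. In this assay compound 2 gives > 10000 nM. For the measured compounds named here, both values sit at the limit of > 10000 nM in this assay, at which 2 of the 2 values shown sit, so the measured set gives no order between compound 1 and compound 2 and no measured step of the kind followed here.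

Compound 3 `O=C(O)c1csc([C@H]2CC[C@@H]3[C@@H](COc4ccc(OC(F)(F)F)cc4)[C@H](O)C[C@@H]3O2)n1` is the compound still to be measured. It differs from compound 1 by trifluoromethoxy in place of trifluoromethyl on an aromatic carbon. Going by the values given here, no measured pair shows what such a swap does in this assay, so the expectation rests on compound 1 alone. Because compound 1 reaches only the limit > 10000 nM, the expected step is a step that the limit leaves unreadable from compound 1 to compound 3, that is, none beyond the usual scatter. Compound 3 is therefore expected to give about 20000 nM, within a range from 5000 nM to 100000 nM, and most likely the assay will again report only a limit.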

Compound 3, half-maximal effective concentration: 4500 nM
The estimate for compound 3 lay 4.4-fold (0.65 log units) above the measured number; the whole stated range lies above it.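

Swapping trifluoromethyl for trifluoromethoxy on the aromatic carbon para to a large group produces an at least 2.2-fold lower number from compound 1 to compound 3 (0.34 log units; beyond the scatter) in this assay and gives the only value in this set that is not a limit. The rest of the structure stays the same, so this position is shown to respond to a change in a single group, here one that adds an oxygen atom and a hydrogen-bond acceptor to the count. The step can be stated only as a minimum, because the starting value for compound 1 is a limit rather than a number: the limit of > 10000 nM in this assay, at which 2 of the 3 values shown sit.

The compounds shown do not reveal whether the inserted oxygen or some other feature of the new group accounts for the step, and a methoxy group, a chlorine atom or a nitrile at the same carbon would help to separate these possibilities. Going by these compounds, it also remains open whether trifluoromethoxy would have a similar effect on the longer chain of compound 2, whose unsubstituted aromatic ring offers a different setting for the same group.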